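Fluoro removal next step in the cyano benzimidazole series

This account rests on a few compounds, and the source may have more. Where it says the series, first, only, none or still open, it means among the compounds named here.

Measured so far in an assay on V79 cells for inhibition of cytochrome P450 11B1, mitochondrial (Homo sapiens), read by HTRF, with a stated time of 1 h; a lower number here means a stronger inhibitor, a higher number a weaker inhibitor:
compound 1 `N#Cc1cc2c(cc1F)nc(-c1cccnc1)n2C1CC1`: 117 nM
compound 2 `Fc1ccc2c(c1)nc(-c1cccnc1)n2C1CC1`: 3980 nM

Compound 1 gives the lowest of the two numbers in this assay ; compound 2 is the nearest, and the step of a 34-fold higher number from compound 1 to compound 2 (1.53 log units; beyond the scatter) shows how much the cyano group carries. Compound 3 `N#Cc1ccc2nc(-c3cccnc3)n(C3CC3)c2c1` is not yet measured. It differs from compound 1 by hydrogen in place of fluoro on an aromatic carbon. For the measured compounds named here, no measured step bears directly on this change; the only measured step, a 34-fold higher number from compound 1 to compound 2 (1.53 log units; beyond the scatter), concerns the cyano group and not the fluoro. With the cyano group kept, a small step is expected for compound 3, a 1.9-fold higher number from compound 1 to compound 3 (0.27 log units; within the scatter), with a slight weakening more likely than a gain. Compound 3 is therefore estimated at 220 nM, within 70 nM to 700 nM.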

Compound 3, half-maximal inhibitory concentration: 374 nM
For compound 3 the middle estimate is 1.7-fold (0.23 log units) below the measured one; low and high end bracket the measured number.
By their numbers in this assay, from the lowest: compound 1; then compound 3; then compound 2.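

The fluoro ortho to a cyano group counts in this assay: the change to hydrogen gives a 3.2-fold higher number from compound 1 to compound 3 (0.50 log units; beyond the scatter) and so lies beyond the scatter, which the earlier pair could not show. This step is modest beside a 34-fold higher number from compound 1 to compound 2 (1.53 log units; beyond the scatter), so of the two changes made from compound 1, loss of the cyano group is the larger. Nothing available gives a reason for the effect of the fluoro at this position.

As far as these compounds go, whether this effect is particular to fluoro stays open, as chloro, methoxy or an amine on the same aromatic carbon could show whether other groups match it or go beyond it. Also open, from the compounds shown here alone, is how the change from fluoro to hydrogen behaves when the cyano group is absent.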